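Moving a Trifluoromethyl Group on a Weaker Core

A few compounds are considered here, and "the series" means these few. Any claim that something is new, unique, unknown or untested is made for them only; others in the source may bear on it.

Measured compounds:
compound 1 `CN(C(=O)NC(=O)c1ccc(F)c(F)c1)c1nc(C(F)(F)F)c(C(=O)N/N=C/c2ccccc2C(F)(F)F)s1` — 3.66 ug/mL
compound 2 `Cc1nc(N(C)C(=O)NC(=O)c2c(F)cccc2F)sc1C(=O)N/N=C/c1cccc(C(F)(F)F)c1` — 32.7 ug/mL
compound 3 `CN(C(=O)NC(=O)c1ccc(F)c(F)c1)c1nc(C(F)(F)F)c(C(=O)N/N=C/c2cccc(C(F)(F)F)c2)s1` — 4.46 ug/mL

In a functional assay on BCG823 cells (Homo sapiens) for inhibition, read by MTT assay, with a stated time of 72 h (a lower number here means a stronger inhibitor, a higher number a weaker inhibitor), compound 1 gives 3.66 ug/mL and compound 3 gives 4.46 ug/mL. These two share a core and differ only in the change (2-(trifluoromethyl)phenyl in place of 3-(trifluoromethyl)phenyl on a carbon with a double bond to nitrogen), which made the step of a 1.2-fold lower number from compound 3 to compound 1 (0.09 log units; within the scatter). Compound 2 gives 32.7 ug/mL in this assay; the difference between its core and the core of compound 3 is not broken down here, and the two values show that compound 2 carries the highest number of the three.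

Compound 4 `Cc1nc(N(C)C(=O)NC(=O)c2c(F)cccc2F)sc1C(=O)N/N=C/c1ccccc1C(F)(F)F` is not yet measured. It arises from compound 2 by 2-(trifluoromethyl)phenyl in place of 3-(trifluoromethyl)phenyl on a carbon with a double bond to nitrogen, the same kind of change as from compound 3 to compound 1. Because that earlier step was a 1.2-fold lower number from compound 3 to compound 1 (0.09 log units; within the scatter), compound 4 is expected to stay close to compound 2, an estimated step of a 1.2-fold lower number from compound 2 to compound 4 (0.07 log units; within the scatter). On that basis compound 4 is estimated at 28 ug/mL in this assay, expected to fall between 14 ug/mL and 56 ug/mL.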

Compound 4, half-maximal inhibitory concentration: 7.88 ug/mL
Compound 4: the middle estimate sits 3.6-fold (0.55 log units) above what was measured; measured number below the stated range.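

In this assay, the same exchange of 3-(trifluoromethyl)phenyl for 2-(trifluoromethyl)phenyl now gives a 4.1-fold lower number from compound 2 to compound 4 (0.62 log units; beyond the scatter), and set beside the earlier step it does not carry over from one core to the other at the same size: the same change on two cores in this assay, a 1.2-fold lower number (0.09 log units; within the scatter) from compound 3 to compound 1 and a 4.1-fold lower number (0.62 log units; beyond the scatter) from compound 2 to compound 4, 3.4-fold (0.53 log units) apart, beyond the scatter of two such steps. The size of this change therefore depends on the core, at least for these two, with a step within the scatter on one and beyond it on the other. This does not show which of the differences between the two cores sets the size of the step, as they differ in more than one place, and two cores give no rule for any others in the series.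

On these data alone, it remains open how a core carrying only some of these differences would respond to the same exchange. Also open, as far as these compounds go, is whether the step would look the same with a different group in place of the trifluoromethyl group, such as a nitrile or a methoxy group.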